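The source may report more compounds than this note shows. Statements on the series, on what has been measured and on what is new or still open speak of the compounds shown alone.

Working notes on the series. Three compounds have been run in a functional assay on T-24 cells (Homo sapiens) for antiproliferative activity, read by MTT assay, with a stated time of 48 h (a lower number here means a stronger inhibitor, a higher number a weaker inhibitor), so far. Compound 1 `O=C(Nc1cccc(CNc2nccnc2Cl)c1)Nc1cccc2ccccc12` returns only a limit in this assay, > 40000 nM. Compound 2 `O=C(Nc1cccc(CNc2nccnc2Cl)c1)Nc1ccccc1F` gives 7450 nM in this assay, and compound 3 `CCc1ccc(NC(=O)Nc2cccc(CNc3nccnc3Cl)c2)c(CC)c1` gives 6390 nM. Compound 2 thus holds the higher of the two numbers in this assay, but its nearest neighbour, compound 3, lies within the scatter of it, so no order between the two can be read. The only other point of reference is the limit of > 40000 nM in this assay, at which 1 of the 3 values shown sits, which says nothing about how far a substituted phenyl urea could move.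

Compound 4 `Cc1ccccc1NC(=O)Nc1cccc(CNc2nccnc2Cl)c1` is the next analogue: against compound 2 it shows (methyl in place of fluoro on an aromatic carbon). The 2-fluorophenyl group of compound 2 becomes a 2-methylphenyl group, with no change in ring count, donors, acceptors or charge.

For the measured compounds named here, no measured pair differs by exactly this exchange, so its size can only be guessed. Given that compound 2 at 7450 nM and compound 3 at 6390 nM sit within the scatter of each other despite different substituents on the same ring, the expected step from compound 2 to compound 4 in this assay is a 1.1-fold lower number from compound 2 to compound 4 (0.03 log units; within the scatter), that is none beyond the scatter, in either direction. The estimate for compound 4 in this assay is therefore 7000 nM, within a range of 3000 nM to 20000 nM.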

Compound 4, half-maximal inhibitory concentration: 13600 nM
Compound 4: middle estimate off by 1.9-fold (0.29 log units), on the low side; measured number inside the range.
By their numbers in this assay, from the lowest: compounds 3, 2 and 4 (each within the scatter of the next, the first and the last beyond it). At a limit, above all of these: compound 1.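

For the compounds shown here, this is the first step between two compounds that differ in one place: in this assay, methyl in place of fluoro on an aromatic carbon, ortho to a large group, gives a 1.8-fold higher number from compound 2 to compound 4 (0.26 log units; within the scatter). Going by these compounds alone, the 2-fluorophenyl and 2-methylphenyl groups are therefore not told apart by this assay, and this single exchange gives no measurable direction at this position, although it is the only exchange tried there so far. No measurement among those shown bears on why the step has this size.

Open, going by these compounds, is whether a group of another kind on the same aromatic carbon, such as an amine, a hydroxyl, a carboxylic acid or a longer chain, would give a step beyond the scatter, and whether the plain phenyl group would differ from the 2-fluorophenyl and 2-methylphenyl groups. For compound 1 the series holds only a limit of the assay, > 40000 nM, not a number.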